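Cryptophycin-like macrocycles: a hydroxy-methoxyphenyl variant awaits measurement

The source may report more compounds than this note shows. Statements on the series, on what has been measured and on what is new or still open speak of the compounds shown alone.

Measured compounds:
compound 1 `CO[C@@H]1C[C@@H]2O[C@@]2(C)C(=O)N[C@@H](C(C)C)C(=O)N[C@H](Cc2cc(Cl)c(O)c(Cl)c2)C(=O)N[C@@H](C(C)(C)O)C(=O)O[C@H](c2ccccc2)[C@H](C)/C=C/C=C/1C` gives "not active" (no number reported)
compound 2 `CC[C@H](C)[C@H]1C(=O)N[C@H](Cc2ccccc2)C(=O)N[C@@H](C(C)(C)O)C(=O)O[C@H](c2ccccc2)[C@H](C)/C=C/C=C(\C)[C@H](OC)C[C@@H]2O[C@@]2(C)C(=O)N1C` gives 20.9 nM
compound 3 `CO[C@@H]1C/C=C(\C)C(=O)N(C)[C@@H](C(C)C)C(=O)N[C@H](Cc2ccccc2)C(=O)N[C@@H](C(C)C)C(=O)O[C@H](c2ccccc2)[C@H](C)/C=C/C=C/1C` gives > 100 nM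

Among the measured compounds shown here, in a functional assay on HCT-116 cells (Homo sapiens) for antiproliferative activity, read by MTT assay, with a stated time of 72 h (on this read-out lower numbers stand for stronger inhibition and higher numbers for weaker inhibition), compound 2 gives 20.9 nM, the only single number among the three. For compound 1 the result is recorded as "not active" (no number reported), without a number. For compound 3 the read-out is a limit of this assay, > 100 nM, so compound 3 stands at the limit of > 100 nM in this assay, at which 1 of the 3 values shown sits; where it lies beyond that limit is not known. For the measured compounds named here, since no two of the measured compounds differ in one place only, no measured step can be drawn between them.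

Compound 4 `COc1cc(C[C@H]2NC(=O)[C@H](C(C)C)N(C)C(=O)/C(C)=C/C[C@@H](OC)/C(C)=C/C=C/[C@@H](C)[C@@H](c3ccccc3)OC(=O)[C@H](C(C)C)NC2=O)ccc1O` is derived from compound 3 by a single change, (4-hydroxy-3-methoxyphenyl in place of phenyl on a saturated chain carbon bound to a saturated ring carbon). Compound 3 sits at a limit, so the step to compound 4 cannot be read against a number. The expectation is that compound 4 also lies beyond that limit, with a step that the limit leaves unreadable from compound 3 to compound 4 not reliably beyond the scatter. Compound 4 is therefore estimated at 300 nM, within 100 nM to 3000 nM.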

Compound 4, half-maximal inhibitory concentration: 48.5 nM
The estimate for compound 4 lay 6.2-fold (0.79 log units) above the measured number; measured number below the stated range.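

In this assay, putting 4-hydroxy-3-methoxyphenyl in place of phenyl on a saturated chain carbon bound to a saturated ring carbon gives an at least 2.0-fold lower number from compound 3 to compound 4 (0.31 log units; beyond the scatter). Among the compounds shown here, this is the first step that can be read in this set: none of the earlier compounds differed in one place only, so they could not show that this position carries the substituted ring with a lower number rather than a loss. The step is only a minimum, since compound 3 stands at a limit of the assay: the limit of > 100 nM in this assay, at which 1 of the 4 values shown sits.

The compounds shown do not separate the hydroxy part of the change from the methoxy part. As far as these compounds go, how an amine or a carboxylic acid on the same ring would read also remains open.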